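The compounds below may be only part of what the source reports. "The series", "measured", "known", "first", "only" and "open" are said of these compounds alone.

In a functional assay on WM164 cells (Homo sapiens) for antiproliferative activity, read by sulforhodamine B assay, with a stated time of 48 h (a lower number here means a stronger inhibitor, a higher number a weaker inhibitor), compound 1 `CCCCCCCCCCNC(=O)[C@@H]1CSC(c2cc(OC)c(OC)c(OC)c2)N1` gives 2100 nM and compound 2 `CCCCCCCCCCCCCCCCNC(=O)[C@@H]1CSC(c2cc(OC)c(OC)c(OC)c2)N1` gives 700 nM. Going by the values given here, the only measured step is a 3.0-fold lower number from compound 1 to compound 2 (0.48 log units; beyond the scatter), with hexyl in place of hydrogen on a saturated chain carbon. Compound 2 therefore holds the lower of the two numbers and is the stronger inhibitor of the pair.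

Compound 3 `CCCCCCCCCCCCCCCCNC(=O)[C@@H]1CSC(c2ccc(N)cc2)N1` keeps the chain of compound 2 but carries 4-aminophenyl in place of 3,4,5-trimethoxyphenyl on a saturated ring carbon, next to the ring nitrogen and next to the ring sulfur: 4-aminophenyl in place of 3,4,5-trimethoxyphenyl on a saturated ring carbon. Among the compounds with values here, no measured step touches this aryl group, as the one available step changes only the chain. That step can therefore serve only as a rough yardstick of size, and the data do not settle the direction. A modest move toward a higher number is the tentative expectation, starting from compound 2 at 700 nM.

The estimated change is a 1.4-fold higher number from compound 2 to compound 3 (0.15 log units; within the scatter). For compound 3 the expected value is 1000 nM, with an estimated range from 300 nM to 3500 nM.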

Compound 3, half-maximal inhibitory concentration: 1400 nM
Compound 3: middle estimate off by 1.4-fold (0.15 log units), on the low side; low and high end bracket the measured number.
By their numbers in this assay, from the lowest: compounds 2, 3 and 1 (each within the scatter of the next, the first and the last beyond it).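

Going by these compounds alone, the change from 3,4,5-trimethoxyphenyl to 4-aminophenyl is the first measured change at this saturated ring carbon, next to the ring nitrogen and next to the ring sulfur; the earlier step touched only the chain. In this assay, it gives a 2.0-fold higher number from compound 2 to compound 3 (0.30 log units; within the scatter). With the chain held constant, this pair therefore shows that the aryl group can go from 12 heavy atoms to 7, lose all three oxygens and gain a nitrogen, with one hydrogen-bond donor where there was none, without the two compounds being separated beyond the scatter. The data offer no explanation for this result.

A single pair cannot show whether the three methoxy groups and the amino group are each dispensable, so an unsubstituted phenyl, 4-methoxyphenyl or 4-hydroxyphenyl group at the same carbon remains an open case. From the compounds shown here alone, it is also open whether 4-aminophenyl would read the same way on the shorter chain of compound 1, or whether a carboxylic acid on the aryl ring would be accommodated at this position.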